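From a Methyl Ether to an Oxolane Ether on Compound 1

The compounds below may be only part of what the source reports. "The series", "measured", "known", "first", "only" and "open" are said of these compounds alone.

Compound 1 `C/C=C/C(=O)Nc1cc2c(N3CCCc4ccccc43)ncnc2cc1OC` is measured in a functional assay on PC-3 cells (Homo sapiens) for antiproliferative activity, read by MTT assay, with a stated time of 72 h (a lower number here means a stronger inhibitor, a higher number a weaker inhibitor), where compound 1 gives 7520 nM. Among the three measured compounds it stands second highest: compound 2 `COc1cc2ncnc(N3CCCc4ccccc43)c2cc1NC(=O)/C=C/C(C)C` gives 8430 nM, a change of a 1.1-fold higher number from compound 1 to compound 2 (0.05 log units; within the scatter), and compound 3 `CCC/C=C/C(=O)Nc1cc2c(N3CCCc4ccccc43)ncnc2cc1OC` gives 2240 nM, a change of a 3.4-fold lower number from compound 1 to compound 3 (0.53 log units; beyond the scatter). Between those two, a 3.8-fold lower number from compound 2 to compound 3 (0.58 log units; beyond the scatter). Compound 4 `C/C=C/C(=O)Nc1cc2c(N3CCCc4ccccc43)ncnc2cc1O[C@@H]1CCOC1` differs from compound 1 by oxolan-3-yl in place of methyl on an oxygen on an aromatic ring. All three measured steps alter the unsaturated chain of the amide and leave this oxygen untouched, so none bears directly on the new change, and no step beyond the scatter is expected in this assay. Compound 4 is therefore estimated at 7000 nM, within 2500 nM to 20000 nM. The expected step is a 1.1-fold lower number from compound 1 to compound 4 (0.03 log units; within the scatter).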

Compound 4, half-maximal inhibitory concentration: 9350 nM
The estimate for compound 4 lay 1.3-fold (0.13 log units) below the measured number; low and high end bracket the measured number.
By their numbers in this assay, from the lowest: compound 3; then compounds 1, 2 and 4 (each within the scatter of the next).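

Placing oxolan-3-yl on this oxygen brings five heavy atoms, a ring, a hydrogen-bond acceptor and a defined stereocentre where methyl had one heavy atom, yet it gives a 1.2-fold higher number from compound 1 to compound 4 (0.09 log units; within the scatter) in this assay and stays within the scatter. Within the data shown here, the earlier steps all changed the amide chain, so this is the first sign that the ether group on the aromatic ring can grow this far without a clear shift in the number.

Still open, from the compounds shown here alone, is whether a longer chain ending in an amine would behave the same way on this oxygen. No measurement here explains the result.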